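The source may hold more compounds than are shown below. What is called first, only, known or untested is meant among the compounds shown, and "the series" means these compounds.

Measured so far:
- compound 1, `COc1ccc(-c2csc(N3N=C(c4ccc(F)cc4)CC3c3ccc4c(c3)OCCO4)n2)cc1`: 4430 nM
- compound 2, `Cc1ccc(C2=NN(c3nc(-c4ccc(Br)cc4)cs3)C(c3ccc4c(c3)OCCO4)C2)cc1`: 1680 nM

In a functional assay on B16-F10 cells (Mus musculus) for antiproliferative activity, read by MTT assay, with a stated time of 48 h (on this read-out higher numbers stand for weaker inhibition and lower numbers for stronger inhibition), compound 1 gives 4430 nM, the highest of the two numbers recorded. Compound 2 gives 1680 nM in this assay, a lower number, and the gap between the two lies beyond the usual scatter. Within the data shown here, no step between measured compounds that differ in one place is available, so nothing measured here bears directly on the change below.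

Compound 3, `COc1ccc(-c2csc(N3N=C(c4ccc(Br)cc4)CC3c3ccc4c(c3)OCCO4)n2)cc1`, is not yet measured. It differs from compound 1 as follows: bromo in place of fluoro on an aromatic carbon. Among the measured compounds shown here, with no measured precedent for this change, the step from compound 1 is expected to be small, and a 1.5-fold lower number from compound 1 to compound 3 (0.17 log units; within the scatter) is taken as an estimate that stays close to the scatter, leaning toward a somewhat lower number. For compound 3 in this assay the estimated value is 3000 nM, with a range from 1200 nM to 7500 nM.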

Compound 3, half-maximal inhibitory concentration: 1120 nM
Compound 3: middle estimate off by 2.7-fold (0.43 log units), on the high side; measured number below the stated range.
By their numbers in this assay, from the lowest: compounds 3 and 2 (each within the scatter of the next); then compound 1.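

In this assay, among these compounds, the exchange of 4-fluorophenyl for 4-bromophenyl gives a 4.0-fold lower number from compound 1 to compound 3 (0.60 log units; beyond the scatter) and is the first step that differs in one place, so it shows that the number responds to the halogen at this aromatic carbon, para to a large group. This reading rests on a single pair, with everything else in the structure held constant, and so describes this change on this background only. Nothing available bears on the reason for the step.

Still open, as far as these compounds go, is where chloro, iodo, an amine or a plain hydrogen at this carbon would fall relative to the fluoro and bromo compounds. Also open, from the compounds shown here alone, is whether the same exchange gives a step of similar size when the other aryl substituent on the shared core is changed.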